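Solubility notes: phenoxy-to-phenyl switch in a quinoline series

The source may hold more compounds than are shown below. What is called first, only, known or untested is meant among the compounds shown, and "the series" means these compounds.

Measured compounds in a physicochemical assay for solubility, with a stated time of 18 h, at pH 7.4; on this read-out higher numbers stand for higher solubility and lower numbers for lower solubility:
- compound 1, `COc1cccc(CNCCCNc2ccnc3cc(Oc4ccc(Cl)cc4)ccc23)c1O`, 14500 nM
- compound 2, `COc1cccc(CNCCCNc2ccnc3cc(Oc4ccccc4)ccc23)c1O`, 14500 nM
- compound 3, `COc1cccc(CNCCCNc2ccnc3cc(Oc4ccc(C(C)(C)C)cc4)ccc23)c1O`, 14500 nM

Compound 3 stands level with compounds 1 and 2 in this assay. The three measured steps all vary the group on the aromatic carbon of the phenoxy ring: no change at the digits printed from compound 1 to compound 2 (within the scatter); no change at the digits printed from compound 1 to compound 3 (within the scatter); no change at the digits printed from compound 2 to compound 3 (within the scatter). None of them moved the read-out beyond the scatter.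

Compound 4, `COc1ccc(-c2ccc3c(NCCCNCc4cccc(OC)c4O)ccnc3c2)cc1`, differs from compound 3 as follows: 4-methoxyphenyl in place of 4-(tert-butyl)phenoxy on an aromatic carbon. This change is not of the same kind as the measured steps: it replaces the whole 4-(tert-butyl)phenoxy group, including its oxygen link, with a 4-methoxyphenyl group bound directly to the aromatic carbon. Going by the values given here, no measured pair shows such a change, so the measured steps bear on it only indirectly, by showing that the read-out sat unchanged across three different groups at this position.

Given that, the expected step is no change at the digits printed from compound 3 to compound 4 (within the scatter), no change beyond the scatter. Among the compounds with values here, the estimated value for compound 4 in this assay is 14500 nM, with a range from 6000 nM to 30000 nM, the width reflecting that no measured step covers this kind of change.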

Compound 4, solubility: 32000 nM
Estimate against measurement, compound 4: 2.2-fold (0.34 log units) below; the measured number lies above the stated range.
By their numbers in this assay, from the lowest: compounds 1, 2 and 3 (each within the scatter of the next); then compound 4.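

In this assay, the chloro, hydrogen and tert-butyl forms of the phenoxy group gave no step beyond the scatter, whereas the 4-methoxyphenyl group does: a 2.2-fold higher number from compound 3 to compound 4 (0.34 log units; beyond the scatter), a 2.2-fold higher number from compound 2 to compound 4 (0.34 log units; beyond the scatter) and a 2.2-fold higher number from compound 1 to compound 4 (0.34 log units; beyond the scatter), all of the same modest size. This position is therefore not silent to every change: varying the group on the phenoxy ring left the read-out level, while replacing the whole group, including its oxygen link, moved it beyond the scatter. No supporting data are available to explain this rise.

The compounds shown cannot separate the loss of the oxygen link from the arrival of the methoxy group, since both come in the same change, and the 4-methoxyphenoxy group and the plain phenyl group bound directly to the same aromatic carbon are the pair that would tell them apart. From the compounds shown here alone, it also remains open how far the read-out moves with other groups on the directly bound phenyl ring, such as a carboxylic acid or an amine.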